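The compounds below may be only part of what the source reports. "The series", "measured", "known", "first", "only" and "open" are said of these compounds alone.

Measured in an ADME assay on L1210/0 cells (Mus musculus) for cytotoxicity, with a stated time of 48 h; a lower number here means a stronger inhibitor, a higher number a weaker inhibitor:
- Compound 1 `O=c1[nH]c(=O)n([C@H]2C[C@H](O)[C@@H](CO)O2)cc1/C=C/I`: 63900 nM
- Compound 2 `O=c1[nH]c(=O)n([C@H]2C[C@H](O)[C@@H](CO)O2)cc1C#CCCCO`: > 200000 nM

Compound 2 gives > 200000 nM in this assay, which is a limit of the assay and not a number. Compound 3 `CC#Cc1cn([C@H]2C[C@H](O)[C@@H](CO)O2)c(=O)[nH]c1=O` differs from it by hydrogen in place of 2-hydroxyethyl on a saturated chain carbon bound to a triple-bonded carbon, so that 5-hydroxypent-1-yn-1-yl becomes prop-1-yn-1-yl. Among the compounds with values here, only one measured step bears on this, and only indirectly: an at least 3.1-fold higher number from compound 1 to compound 2 (0.49 log units; beyond the scatter). That step put 5-hydroxypent-1-yn-1-yl in place of 2-iodoethenyl, so shortening the chain is expected to give a modestly lower number, though staying at the limit remains possible. The expected change is an at least 2.2-fold lower number from compound 2 to compound 3 (0.34 log units; beyond the scatter). For compound 3 the estimate is 90000 nM, with an expected range of 25000 nM to 200000 nM.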

Compound 3, half-maximal inhibitory concentration: > 200000 nM
Compound 3: a limit, no number; the forecaster's own chance of this, stated with the estimate: 35%; middle value at least 2.2-fold (0.34 log units) from the limit.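

In this assay, the shorter chain gives no measurable value either: prop-1-yn-1-yl, like 5-hydroxypent-1-yn-1-yl, stays at the limit of the assay. Putting prop-1-yn-1-yl in place of 2-iodoethenyl gives an at least 3.1-fold higher number from compound 1 to compound 3 (0.49 log units; beyond the scatter), so the loss does not depend on the 2-hydroxyethyl part of the longer chain. The step between compound 2 and compound 3 cannot be read, since both values are limits: the limit of > 200000 nM in this assay, at which 2 of the 3 values shown sit.

As far as these compounds go, how far past the limit either compound lies stays unknown. From the compounds shown here alone, whether an amine or a carboxylic acid on the chain would bring a measurable number in this assay also stays open.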